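Demethylation of the Aryl Ether in a Trifluoromethyl Ketone Hydrate

The source may report more compounds than this note shows. Statements on the series, on what has been measured and on what is new or still open speak of the compounds shown alone.

Compound 1 `COc1ccc(-c2cnc(NC(=O)CCCCCCNC(=O)C(O)(O)C(F)(F)F)s2)cc1` is the strongest of the three measured compounds in an assay on isolated protein for inhibition of protein deacetylase HDAC6 (Homo sapiens), read by chemiluminescence, with a stated time of 3 h (a lower number here means a stronger inhibitor, a higher number a weaker inhibitor), where compound 1 gives 37000 nM. Compound 3 `O=C(CCCCCCNC(=O)C(O)(O)C(F)(F)F)Nc1ccc(Br)cc1` gives 100000 nM, and compound 2 `COc1ccc(NC(=O)CCCCCCNC(=O)C(O)(O)C(F)(F)F)cc1` gives 440000 nM. Among the measured compounds shown here, the only single-point step among them, a 4.4-fold lower number from compound 2 to compound 3 (0.64 log units; beyond the scatter), concerns a substituent on an aromatic carbon of a different core and was modest. The step to compound 4 `O=C(CCCCCCNC(=O)C(O)(O)C(F)(F)F)Nc1ncc(-c2ccc(O)cc2)s1` is hydrogen in place of methyl on an oxygen on an aromatic ring: methoxy to hydroxy, 4-methoxyphenyl to 4-hydroxyphenyl, on the aryl group attached to the core of compound 1. For the measured compounds named here, no measured step changes this same oxygen, so the step from compound 2 to compound 3 is the only guide, and it shows that a small change on this kind of aromatic ring moves the number by a modest amount. Compound 4 is therefore expected to land near compound 1, with a step of a 1.2-fold lower number from compound 1 to compound 4 (0.09 log units; within the scatter) that may be within the scatter, and its estimated value is 30000 nM, in a range from 12000 nM to 80000 nM.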

Compound 4, half-maximal inhibitory concentration: 210000 nM
Compound 4: the middle estimate sits 7.0-fold (0.85 log units) below what was measured; the measured number lies above the stated range.
By their numbers in this assay, from the lowest: compound 1; then compound 3; then compound 4; then compound 2.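

In this assay, the oxygen on the aryl group attached to the core of compound 1 proves sensitive to a small edit: methoxy to hydroxy gives a 5.7-fold higher number from compound 1 to compound 4 (0.75 log units; beyond the scatter), a step beyond the scatter towards a weaker inhibitor. Among the compounds shown here, the earlier step, a 4.4-fold lower number from compound 2 to compound 3 (0.64 log units; beyond the scatter), replaced the whole substituent on a different core, so this is the first measured change to the group on this oxygen itself, and here the methyl goes with the stronger number. No supporting measurement bears on this result, so the compounds give no account of the loss.

From the compounds shown here alone, it remains open whether a longer ether such as ethoxy would keep the number of compound 1, or an amine in place of the hydroxy would recover it. Going by these compounds, whether methoxy to hydroxy would move the number the same way on the core of compound 2 also remains open.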